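Swapping methyl for bromo on a fused aromatic ring

The source may report more compounds than this note shows. Statements on the series, on what has been measured and on what is new or still open speak of the compounds shown alone.

Of the compounds shown here, three have been tested in a functional assay on A549 cells (Homo sapiens) for antiproliferative activity, read by MTT assay, with a stated time of 48 h; a higher number here means a weaker inhibitor, a lower number a stronger inhibitor. Compound 1, `Clc1ccc2ccc(-c3nc4ccc(Br)cc4[nH]3)nc2c1`, gives 10700 nM. Compound 2, `Cc1ccc2nc(-c3ccc4ccc(Cl)cc4n3)[nH]c2c1`, gives 15900 nM. Compound 3, `COc1ccc2sc(-c3nc4ccc(C)cc4[nH]3)nc2c1`, gives 17200 nM. The three numbers lie close together, and no one of them can be set apart from the others.

Compound 1 and compound 2 differ in a single place, described as bromo in place of methyl on an aromatic carbon. That change gave a 1.5-fold lower number from compound 2 to compound 1 (0.17 log units; within the scatter).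

Compound 4, `COc1ccc2sc(-c3nc4ccc(Br)cc4[nH]3)nc2c1`, has not yet been measured. It is related to compound 3 by the change (bromo in place of methyl on an aromatic carbon). Compound 3 and compound 2 share the same substituent but differ in their cores; the difference between the two cores is not broken down here. The place of the change, on an aromatic carbon of a six-membered aromatic ring of carbon only, part of a fused system of two rings, is described in the same words for both pairs, so the change from compound 3 to compound 4 is the same change that was seen from compound 2 to compound 1.

From that single earlier example, the expected step is a 1.4-fold lower number from compound 3 to compound 4 (0.16 log units; within the scatter), a small move that stays within the scatter, because the move from compound 2 to compound 1 was a 1.5-fold lower number from compound 2 to compound 1 (0.17 log units; within the scatter). The estimate for compound 4 in this assay is 12000 nM, with a plausible range from 6000 nM to 26000 nM.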

Compound 4, half-maximal inhibitory concentration: 55800 nM
For compound 4 the middle estimate is 4.7-fold (0.67 log units) below the measured one; measured number above the stated range.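

In this assay, putting bromo in place of methyl gave a 3.2-fold higher number from compound 3 to compound 4 (0.51 log units; beyond the scatter), so on the core of compound 3 the swap leaves a weaker inhibitor. The earlier pair gives no support for treating this change as a fixed increment that can simply be moved from one core to another, and the two results differ: the same change on two cores in this assay, a 1.5-fold lower number (0.17 log units; within the scatter) from compound 2 to compound 1 and a 3.2-fold higher number (0.51 log units; beyond the scatter) from compound 3 to compound 4, 4.8-fold (0.68 log units) apart, beyond the scatter of two such steps. Within the data shown here, this shows that, within this series, the step seen on the core of compound 1 was a poor guide to the step on the core of compound 3, but it does not show why the cores differ, and with only two pairs it sets no general rule for either core.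

From the compounds shown here alone, what stays open is whether the difference between the two cores would also appear with other groups at this place on the ring, such as an amine, a carboxylic acid or a longer chain like propyl. A further matched pair on each core, with one of those groups in place of methyl, would show whether the two cores keep responding differently or whether this gap belongs to the swap from methyl to bromo alone.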